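Dichlorophenyl series: chloro removal on the methyl core

The source may hold more compounds than are shown below. What is called first, only, known or untested is meant among the compounds shown, and "the series" means these compounds.

Measured so far:
compound 1, `C=CCn1c(=O)/c(=C\c2cccc(Cl)c2)[nH]c(=O)/c1=C\c1ccccc1OC`, 4500 nM
compound 2, `C=CCn1c(=O)/c(=C\c2cccc(Cl)c2Cl)[nH]c(=O)/c1=C\c1ccccc1OC`, 2000 nM
compound 3, `COc1ccccc1/C=c1\c(=O)[nH]/c(=C/c2cccc(Cl)c2Cl)c(=O)n1C`, 200 nM

All numbers come from a functional assay on HL-60 cells (Homo sapiens) for cytotoxicity, read by CCK-8 assay, with a stated time of 72 h; a lower number here means a stronger inhibitor, a higher number a weaker inhibitor. Compound 2 and compound 3 differ in the core, as hydrogen in place of vinyl on a saturated chain carbon bound to an aromatic nitrogen, and the step of a 10-fold lower number from compound 2 to compound 3 (1.00 log units; beyond the scatter) leaves compound 3 with the lowest number of the three.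

The change now to be read is hydrogen in place of chloro on an aromatic carbon, giving compound 4, `COc1ccccc1/C=c1\c(=O)[nH]/c(=C/c2ccccc2Cl)c(=O)n1C`. The same kind of change stands measured once already, (hydrogen in place of chloro on an aromatic carbon), with the step of a 2.3-fold higher number from compound 2 to compound 1 (0.35 log units; beyond the scatter); the place differs in that the earlier one is ortho to a large group while the new one is meta to a large group, so it is the same kind of change, not the same. Resting on the step of a 2.3-fold higher number from compound 2 to compound 1 (0.35 log units; beyond the scatter), a modest rise is expected for compound 4, a 2.3-fold higher number from compound 3 to compound 4 (0.35 log units; beyond the scatter). The number expected for compound 4 in this assay is 450 nM, between 150 nM and 1500 nM.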

Compound 4, half-maximal inhibitory concentration: 200 nM
Compound 4: the middle estimate sits 2.3-fold (0.35 log units) above what was measured; measured number inside the range.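

In this assay, going from 2,3-dichlorophenyl to 2-chlorophenyl gives no change at the digits printed from compound 3 to compound 4 (within the scatter). Set beside the same change on the other core, the two steps do not separate: the same change on two cores in this assay, a 2.3-fold higher number (0.35 log units; beyond the scatter) from compound 2 to compound 1 and no change at the digits printed (within the scatter) from compound 3 to compound 4, 2.3-fold (0.35 log units) apart, within the scatter of two such steps. The change therefore carries across these two cores without a gap that can be told from the scatter, but this rests on a single pair per core, with the chloro leaving a different place in each pair, and it sets no rule for other cores or other positions.

The compounds shown leave open how a phenyl with no chloro at all would read on either core, and how a fluoro or an amine would read in place of the remaining chloro. Going by these compounds, a longer chain in place of the methyl on the core also remains open.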